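This account rests on a few compounds, and the source may have more. Where it says the series, first, only, none or still open, it means among the compounds named here.

Measured in a functional assay on U-87MG ATCC cells (Homo sapiens) for cytotoxicity, read by MTT assay, with a stated time of 72 h; on this read-out lower numbers stand for stronger inhibition and higher numbers for weaker inhibition:
- compound 1 `COc1ccc(OC)c(/C=N/NC(=O)Nc2ccc(Oc3ccnc(-c4nncn4CCN(C)C)c3)c(F)c2)c1`: 6400 nM
- compound 2 `CN(C)CCn1cnnc1-c1cc(Oc2ccc(NC(=O)N/N=C/c3cc(Br)c(O)c(Br)c3)cc2F)ccn1`: > 100000 nM (a limit)

Compound 2 gives only a limit of the assay and not a number; this is the limit of > 100000 nM in this assay, at which 1 of the 2 values shown sits. Its true position in this assay is therefore open.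

Compound 3 `CN(C)CCn1cnnc1-c1cc(Oc2ccc(NC(=O)N/N=C/c3cccc(O)c3)cc2F)ccn1` is the next to be read. It has 3-hydroxyphenyl in place of 3,5-dibromo-4-hydroxyphenyl on a carbon with a double bond to nitrogen.

For the measured compounds named here, one measured step bears on this place: an at least 15-fold higher number from compound 1 to compound 2 (1.19 log units; beyond the scatter), which is large and beyond the scatter. That step brought in the 3,5-dibromo-4-hydroxyphenyl that now leaves, so a move back toward compound 1 at 6400 nM is expected. A full return is not assumed, since 3-hydroxyphenyl is not the 2,5-dimethoxyphenyl of compound 1, and a single step is thin support.

In this assay the expected change is an at least 6.6-fold lower number from compound 2 to compound 3 (0.82 log units; beyond the scatter), a large step toward lower numbers, beyond the scatter.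

For compound 3 the estimate is 15000 nM, with an expected range of 4000 nM to 60000 nM.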

Compound 3, half-maximal inhibitory concentration: > 100000 nM
Compound 3 ended at the assay's limit; the forecaster's own chance of this, stated with the estimate: 20%; at least 6.6-fold (0.82 log units) between middle value and limit.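

In this assay compound 3 gives > 100000 nM, which is a limit and not a number. With 3-hydroxyphenyl on the carbon with a double bond to nitrogen, the series shows an at least 15-fold higher number from compound 1 to compound 3 (1.19 log units; beyond the scatter), so the weak read-out at this position does not require the two bromine atoms of compound 2, and among these three compounds only the 2,5-dimethoxyphenyl of compound 1 gives a readable value. The step between compound 2 and compound 3 cannot be read, and no order between them can be stated, as both sit at the same limit: the limit of > 100000 nM in this assay, at which 2 of the 3 values shown sit.

As far as these compounds go, whether the readable value of compound 1 goes with its methoxy groups or with the lack of a ring hydroxyl remains open. An unsubstituted phenyl or a phenyl carrying a single methoxy group at this place would separate these two readings, and only a compound with a value clear of the limit could show how far the hydroxyphenyl compounds really lie from compound 1.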